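A few compounds are considered here, and "the series" means these few. Any claim that something is new, unique, unknown or untested is made for them only; others in the source may bear on it.

In an in vitro ADME assay on microsomes from liver (Homo sapiens) for metabolic stability, read by LC-MS (on this read-out higher numbers stand for a longer-lived compound and lower numbers for a shorter-lived compound), compound 1 `C=CCON/C(=N\C1=NC(=O)C(=O)N1C(C)C)Nc1ccc(Cl)c(Cl)c1` gives > 1 h, which is a limit of the assay and not a number. Compound 2 `CN/C(=N\C1=NC(=O)C(=O)N1C(C)C)Nc1ccc(Cl)c(Cl)c1`, the starting point here, gives > 1 h, also a limit. Compound 3 `CC(C)N1C(=O)C(=O)N=C1/N=C(\NCC(C)(C)C)Nc1ccc(Cl)c(Cl)c1` gives > 1 h, again a limit. The whole record so far is therefore (the limit of > 1 h in this assay, at which 3 of the 3 values shown sit), and compound 2 has no exact half-life to start from.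

Compound 4 `CC(C)N1C(=O)C(=O)N=C1/N=C(\NCc1ccccc1)Nc1ccc(Cl)c(Cl)c1` is compound 2 with phenyl in place of hydrogen on a saturated chain carbon bound to an amine nitrogen, so methylamino becomes benzylamino: phenyl in place of hydrogen on a saturated chain carbon bound to an amine nitrogen.

The closest guide is a step that the two limits leave unreadable from compound 2 to compound 3, where tert-butyl enters at that same place. Two more distant guides, which change allyloxy on an amine nitrogen, are a step that the two limits leave unreadable from compound 1 to compound 2 and a step that the two limits leave unreadable from compound 1 to compound 3. None of the three has a readable size, but compound 3 shows no fall to a number after a step that the two limits leave unreadable from compound 2 to compound 3. No step beyond the usual scatter is therefore expected in this assay, in either direction, and another limit is the likeliest report. The expected change is a step that the limit leaves unreadable from compound 2 to compound 4, a loose estimate. For compound 4 the estimated half-life is 1.5 h, with an expected range of 0.6 h to 4 h.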

Compound 4, half-life: > 1 h
Compound 4 ended at the assay's limit (the forecaster's own chance of this, stated with the estimate: 70%); the middle value does not contradict the limit.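

Compound 4 gives a limit of this assay and not a number, as do compounds 1, 2 and 3, so no step between compound 4 and any of them can be read: the limit of > 1 h in this assay, at which 4 of the 4 values shown sit.

The compounds shown leave open how long each one actually lasts in this assay, and whether phenyl in place of hydrogen changes the half-life at all.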